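Dropping One Fluorine from a Sulfonyl Aryl Ring

This account rests on a few compounds, and the source may have more. Where it says the series, first, only, none or still open, it means among the compounds named here.

Measured compounds:
- Compound 1, `Cc1ccc(S(=O)(=O)c2cnc3ccc(Cl)cc3c2N2CCC(C)CC2)cc1C`, gives 84% in an assay on isolated protein for displacement of a labelled ligand from metabotropic glutamate receptor 5 (Homo sapiens), with a stated time of 60 min, tested at 1 uM; a higher number here means more inhibition at the concentration tested (going by the name of the read-out), a lower number less inhibition.
- Compound 2, `CC1CCN(c2c(S(=O)(=O)c3ccc(F)c(F)c3)cnc3ccc(Cl)cc23)CC1`, gives 72% in this assay.

For the measured compounds named here, of these two numbers, compound 2 stands lowest: the nearest is compound 1, and the only measured step, a number 12 percentage points lower from compound 1 to compound 2 (beyond the scatter), exchanged 3,4-difluorophenyl for 3,4-dimethylphenyl on the sulfonyl sulfur and cost a modest amount of inhibition beyond the scatter.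

Compound 3, `CC1CCN(c2c(S(=O)(=O)c3ccc(F)cc3)cnc3ccc(Cl)cc23)CC1`, has not been measured. It differs from compound 2 by hydrogen in place of fluoro on an aromatic carbon. Cut one bond further out, the change reads 3,4-difluorophenyl to 4-fluorophenyl; the aromatic carbon concerned sits ortho to a fluoro group and meta to a large group.

Going by the values given here, only the step from compound 1 to compound 2 bears on this, and it concerns the same ring, but it swapped two groups at once rather than removing one. Removing a single fluorine is a smaller change, so the expected step of a number 4 percentage points lower from compound 2 to compound 3 (within the scatter) is small, likely within the scatter and slightly downward if anything. Compound 3 is therefore estimated at 68%, within 50% to 86%.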

Compound 3, a percentage reported as inhibition, at one concentration (the size of the read-out at that concentration, not a potency): 89%
Estimate against measurement, compound 3: 21 percentage points below, and the stated range ends below it.
By their numbers in this assay, from the lowest: compound 2; then compounds 1 and 3 (each within the scatter of the next).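

Replacing fluoro with hydrogen on the aromatic carbon ortho to a fluoro group and meta to a large group gives a number 17 percentage points higher from compound 2 to compound 3 (beyond the scatter) in this assay, so even this one-atom change at this position can shift the read-out. The lower number for the 3,4-difluorophenyl ring therefore does not extend to every fluorinated ring here: the 4-fluorophenyl ring still carries a fluoro group, yet the exchange of 3,4-dimethylphenyl for it gives a number 5 percentage points higher from compound 1 to compound 3 (within the scatter). Nothing available here explains why this one fluoro group makes a difference.

The compounds shown leave open whether the remaining fluoro group contributes anything, which a plain phenyl ring would test, and whether chloro or methoxy on the carbon that now bears hydrogen would resemble fluoro or hydrogen. They also leave open whether this order would hold across a full range of concentrations, since each number comes from a single tested concentration and is not a potency.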